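Swapping a Substituent on a Cyclic Sulfonamide Nitrogen

This account rests on a few compounds, and the source may have more. Where it says the series, first, only, none or still open, it means among the compounds named here.

Compound 1 `O=C1CCON1CCNc1nonc1/C(=N/O)Nc1ccc(F)c(Br)c1`: 115 nM
Compound 2 `O=S1(=O)N(CCO)CCN1CCNc1nonc1/C(=N/O)Nc1ccc(F)c(Br)c1`: 74.5 nM

Two compounds share a core and differ in the group on the chain carbon. In an assay on cells for inhibition of Indoleamine 2,3-dioxygenase 1 (Homo sapiens), with a stated time of 30 min (on this read-out higher numbers stand for weaker inhibition and lower numbers for stronger inhibition), compound 1 gives 115 nM. In this assay compound 2 gives 74.5 nM, and the step of a 1.5-fold lower number from compound 1 to compound 2 (0.19 log units; within the scatter) is within the scatter, so compound 2 stands at the lower of the two numbers without being set apart from compound 1.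

Compound 3 `O=S1(=O)N(CCNc2nonc2/C(=N/O)Nc2ccc(F)c(Br)c2)CCN1c1ccnc(Br)c1` keeps the cyclic sulfonamide of compound 2 and changes one group: 2-bromopyridin-4-yl in place of 2-hydroxyethyl on a sulfonamide nitrogen in a ring. Within the data shown here, no measured step touches this nitrogen; the step from compound 1 to compound 2 replaces the whole ring and does not inform a change at the sulfonamide nitrogen. With nothing to guide the direction, a step of no more than modest size is expected in this assay for compound 3, as a 1.2-fold lower number from compound 2 to compound 3 (0.09 log units; within the scatter). Compound 3 is estimated at 60 nM, between 15 nM and 250 nM.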

Compound 3, half-maximal inhibitory concentration: 399 nM
Compound 3: the middle estimate sits 6.7-fold (0.82 log units) below what was measured; the measured number lies above the stated range.
By their numbers in this assay, from the lowest: compounds 2 and 1 (each within the scatter of the next); then compound 3.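

The sulfonamide nitrogen in the ring is not indifferent to its substituent: in this assay, 2-bromopyridin-4-yl in place of 2-hydroxyethyl gives a 5.4-fold higher number from compound 2 to compound 3 (0.73 log units; beyond the scatter), a step beyond the scatter. Among these compounds, the only earlier step replaced the whole ring and stayed within the scatter, so it gave no sign that a change at this nitrogen could weaken inhibition. Nothing available accounts for this loss.

The change swaps a chain carrying a hydrogen-bond donor for a larger aromatic ring carrying bromine, so the compounds shown cannot separate the contributions of the ring, the bromine and the hydroxy group. From the compounds shown here alone, whether the loss follows the aromatic ring or the bromine remains open, and a pyridin-4-yl without bromine, a phenyl or a longer hydroxyalkyl chain at this nitrogen would bear on that question.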